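The source may hold more compounds than are shown below. What is called first, only, known or untested is meant among the compounds shown, and "the series" means these compounds.

Compound 1 `Cc1ccc(CN2C(=O)S/C(=C\c3ccc([N+](=O)[O-])cc3)C2=O)cc1`: 11.4%; compound 2 `Cc1ccc(CN2C(=O)S/C(=C\c3ccccc3Cl)C2=O)cc1`: 43.3% in a functional assay on the whole organism (plasma) with Mus musculus as the target, with a stated time of 15 days, at a dose of 30 mg/kg by the oral route; a higher number here means a stronger effect of the compound at the dose given, a lower number a weaker effect.

Compound 2 stands highest of the two numbers in this assay; its nearest neighbour, compound 1, lies lower by a gap beyond the usual scatter. Compound 3 `Cc1ccc(CN2C(=O)S/C(=C\OCc3ccccc3)C2=O)cc1` has not yet been measured. It differs from compound 2 in one place: benzyloxy in place of 2-chlorophenyl on a double-bonded chain carbon bound to a double-bonded ring carbon. Within the data shown here, no measured pair shows what this change does, so the direction is an expectation only; a downward step of modest size is expected: a number 18.3 percentage points lower from compound 2 to compound 3 (beyond the scatter). Compound 3 is estimated at 25%, with a range from 5% to 50%.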

Compound 3, a percentage reported as activity, at one dose (the size of the read-out at that dose, not a potency): 20.2%
Compound 3: middle estimate off by 4.8 percentage points, on the high side; measured number inside the range.
By their numbers in this assay, from the lowest: compounds 1 and 3 (each within the scatter of the next); then compound 2.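

In this assay, among these compounds, benzyloxy in place of 2-chlorophenyl on a double-bonded chain carbon bound to a double-bonded ring carbon gives the first readable step at this position, a number 23.1 percentage points lower from compound 2 to compound 3 (beyond the scatter). The effect at this dose therefore depends on the group at this place, although this single change cannot separate the loss of the chlorine from the entry of the oxygen. No measurement at hand gives a cause for this step.

Going by these compounds, it remains open what an unsubstituted phenyl would give at this place, which would test the chlorine alone. On these data alone, whether an amine or a carboxylic acid there would raise or lower the effect also remains open.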